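Naphthyloxy Acetohydrazones: Lipophilicity Across the Aryl Group

This account rests on a few compounds, and the source may have more. Where it says the series, first, only, none or still open, it means among the compounds named here.

Measured so far:
compound 1 `O=C(COc1cccc2ccccc12)N/N=C/C=C/c1ccccc1` gives 4.43
compound 2 `O=C(COc1cccc2ccccc12)N/N=C/c1ccc(Br)cc1` gives 4.81
compound 3 `O=C(COc1cccc2ccccc12)N/N=C/c1ccccc1Cl` gives 4.54

All three were measured in a physicochemical assay for lipophilicity, measured as octanol-water partition; a higher number here means a more lipophilic compound, a lower number a more polar compound. Compound 3 sits between the other two numbers, yet neither gap is telling: the step of a number 0.11 log units higher from compound 1 to compound 3 (within the scatter) and the step of a number 0.27 log units lower from compound 2 to compound 3 (within the scatter) both fall within the scatter, and only a number 0.38 log units higher from compound 1 to compound 2 (beyond the scatter) exceeds it. Compound 4 `Cc1ccc(/C=N/NC(=O)COc2cccc3ccccc23)cc1` has not yet been measured. It differs from compound 3 in one place: 4-methylphenyl in place of 2-chlorophenyl on a carbon with a double bond to nitrogen. The step most like this one is a number 0.27 log units lower from compound 2 to compound 3 (within the scatter), an exchange of one halogenated phenyl for another that moved nothing beyond the scatter. A step of similar size is therefore expected here, a number 0.04 log units lower from compound 3 to compound 4 (within the scatter), in no clear direction. Compound 4 is estimated to give 4.5, between 4.2 and 4.85.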

Compound 4, partition coefficient: 4.49
Compound 4: middle estimate off by 0.01 log units, on the high side, within the range that was stated.
By their numbers in this assay, from the lowest: compounds 1, 4, 3 and 2 (each within the scatter of the next, the first and the last beyond it).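

In this assay, among the compounds shown here, methyl in place of bromo on an aromatic carbon gives a number 0.32 log units lower from compound 2 to compound 4 (beyond the scatter) and so makes a second step beyond the scatter, the first being the one that separates compound 2 from compound 1. The other two new steps, a number 0.05 log units lower from compound 3 to compound 4 (within the scatter) and a number 0.06 log units higher from compound 1 to compound 4 (within the scatter), stay within the scatter, so 4-methylphenyl cannot be told apart from 2-chlorophenyl or 2-phenylethenyl at this position. Nothing available explains these numbers. As far as these compounds go, whether an amine or a carboxylic acid on the phenyl ring would carry the number outside this narrow band remains open.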